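Amide for Acid in a Series Without Measured Toxicity

The compounds below may be only part of what the source reports. "The series", "measured", "known", "first", "only" and "open" are said of these compounds alone.

Compound 1 `CCN(CC)C(=O)c1cc2sccc2n1Cc1ccc(OC)cc1`: in an ADME assay on HEK-293T cells (Homo sapiens) for cytotoxicity, read by luminescence, with a stated time of 24 h (on this read-out higher numbers stand for lower toxicity in this test and lower numbers for higher toxicity in this test), compound 1 gives only a limit, > 100000 nM.
Compound 2 `COc1ccc(Cn2c(C(=O)N3CCC(C(=O)O)CC3)cc3sccc32)cc1`: in this assay compound 2 also gives only a limit, > 100000 nM.

Compound 2 therefore stands at the top of what this assay reports, with no number. Within the data shown here, the single measured step, a step that the two limits leave unreadable from compound 1 to compound 2, cannot be sized, since both compounds sit at the limit of > 100000 nM in this assay, at which 2 of the 2 values shown sit. Compound 3 `COc1ccc(Cn2c(C(=O)N3CCC(C(=O)NC4CC4)CC3)cc3sccc32)cc1` carries the change (cyclopropylamino in place of hydroxy on a carbonyl carbon). Among the measured compounds shown here, no measured step reads on this change, so nothing points to a move beyond the scatter. The step expected for a number no higher from compound 2 to compound 3 (the limit leaves the size open) is none beyond the scatter. Compound 3 is accordingly estimated at 100000 nM, between 50000 nM and 200000 nM, most likely again as a limit.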

Compound 3, half-maximal cytotoxic concentration: 21400 nM
Estimate against measurement, compound 3: 4.7-fold (0.67 log units) above; the measured number lies below the stated range.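

On the carbonyl carbon, cyclopropylamino in place of hydroxy gives an at least 4.6-fold lower number from compound 2 to compound 3 (0.66 log units; beyond the scatter) in this assay, so a change at this position can bring toxicity into the range the test can report. From the compounds shown here alone, the true size of the step stays unknown, as only one side of it is a number. Compound 3 is the only compound shown with a measured number: the limit of > 100000 nM in this assay, at which 2 of the 3 values shown sit.

Going by these compounds, whether a plain amino or methylamino group on this carbonyl carbon would also lower the number stays open. So does whether the three-membered ring is needed for the change.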